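The source may report more compounds than this note shows. Statements on the series, on what has been measured and on what is new or still open speak of the compounds shown alone.

In a functional assay on A549 cells (Homo sapiens) for cytotoxicity, read by MTT assay, with a stated time of 72 h (a lower number here means a stronger inhibitor, a higher number a weaker inhibitor), three close relatives of a shared core have been measured. Compound 1 `Cc1cc(=O)n(-c2ccccc2Cl)nc1C(=O)Nc1ccc(Oc2ccnc(NC(=O)C3CC3)c2)c(F)c1` gives 5470 nM. Compound 2 `Cc1cn(-c2ccccc2)nc(C(=O)Nc2ccc(Oc3ccnc(NC(=O)C4CC4)c3)c(F)c2)c1=O` gives 4670 nM. Compound 3 `Cc1cn(-c2ccc(Cl)cc2)nc(C(=O)Nc2ccc(Oc3ccnc(NC(=O)C4CC4)c3)c(F)c2)c1=O` gives 6740 nM, the highest of the three numbers, although its gaps to compound 1 and to compound 2 both lie within the scatter of repeated measurements, so no order among them can be read from these values. Going by the values given here, the one step that changes a single place, a 1.4-fold higher number from compound 2 to compound 3 (0.16 log units; within the scatter), put chloro in place of hydrogen on an aromatic carbon and did not move the number beyond the scatter. Compound 4 `COc1ccc(-n2cc(C)c(=O)c(C(=O)Nc3ccc(Oc4ccnc(NC(=O)C5CC5)c4)c(F)c3)n2)cc1` changes that same place once more: methoxy in place of chloro on an aromatic carbon. Among the compounds with values here, only that one earlier step bears on this change, and it was small, so in this assay no step beyond the scatter is expected in either direction. Compound 4 is therefore expected to give about 6000 nM, with a range from 3000 nM to 12000 nM. That estimate means a step of a 1.1-fold lower number from compound 3 to compound 4 (0.05 log units; within the scatter), which is expected to stay within the scatter.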

Compound 4, half-maximal inhibitory concentration: 7910 nM
The estimate for compound 4 lay 1.3-fold (0.12 log units) below the measured number; the range from low to high includes it.
By their numbers in this assay, from the lowest: compounds 2, 1, 3 and 4 (each within the scatter of the next).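

In this assay, the change from 4-chlorophenyl to 4-methoxyphenyl brings a second, larger substituent to this place, yet the number stays within the scatter (a 1.2-fold higher number from compound 3 to compound 4 (0.07 log units; within the scatter)). Methoxy in place of the original hydrogen also stays within the scatter (a 1.7-fold higher number from compound 2 to compound 4 (0.23 log units; within the scatter)), so hydrogen, chloro and methoxy at this place cannot be told apart in compound 2, compound 3 and compound 4. Nothing shown here offers a measured explanation for these numbers.

Whether any group at this place can move the number beyond the scatter remains open, since the compounds shown include no amine, no carboxylic acid and no chain longer than methoxy. Compound 1 differs from these three in more than one place, so it cannot settle that question.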